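Swapping a methoxy for a methyl on the aryloxy ring

This account rests on a few compounds, and the source may have more. Where it says the series, first, only, none or still open, it means among the compounds named here.

Compound 1 `COc1cccc(Cl)c1OCCNCCOc1ccccc1OCc1ccccc1` and compound 2 `COc1cccc(C)c1OCCNCCOc1ccccc1OCc1ccccc1` share one core and differ only on one aromatic carbon. In an assay on CHO cells for displacement of a labelled ligand from Alpha-1D adrenergic receptor (Homo sapiens) (on this read-out higher numbers stand for weaker inhibition and lower numbers for stronger inhibition), compound 1 gives 0.741 nM, and compound 2 gives 0.912 nM. For the measured compounds named here, the only measured step, a 1.2-fold higher number from compound 1 to compound 2 (0.09 log units; within the scatter), shows that this exchange barely moves the number, so compound 2 sits alongside compound 1 with nothing separating them beyond the scatter. Going by the values given here, compound 3 `Cc1cccc(C)c1OCCNCCOc1ccccc1OCc1ccccc1` follows from compound 2 by a different exchange, (methyl in place of methoxy on an aromatic carbon), so no measured step speaks directly to it. In the absence of such a comparison, the expectation for this assay is a step no larger than a 1.6-fold higher number from compound 2 to compound 3 (0.22 log units; within the scatter), leaning toward a somewhat higher number but possibly still within the scatter. On that basis compound 3 is estimated at 1.5 nM, with a plausible range from 0.5 nM to 4.5 nM.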

Compound 3, inhibition constant: 14.1 nM
For compound 3 the middle estimate is 9.4-fold (0.97 log units) below the measured one; measured number above the stated range.
By their numbers in this assay, from the lowest: compounds 1 and 2 (each within the scatter of the next); then compound 3.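

In this assay, this position proves far more sensitive than the earlier chloro-to-methyl exchange suggested: methyl in place of methoxy gives a 15-fold higher number from compound 2 to compound 3 (1.19 log units; beyond the scatter). The wider exchange, 2,6-dimethylphenyl in place of 2-chloro-6-methoxyphenyl, also gives a large step, a 19-fold higher number from compound 1 to compound 3 (1.28 log units; beyond the scatter), so among these three compounds, the two that keep the methoxy lie within the scatter of each other and the one without it stands apart. Nothing available explains why this exchange has so large an effect on the number.

The compounds shown leave open how an ethoxy, a hydroxyl or a fluoro at this position would read. They also leave open whether methyl in place of methoxy would produce a step of this size on a different core.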